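A Second Chlorine and Growth Inhibition in Breast Cancer Cells

The compounds below may be only part of what the source reports. "The series", "measured", "known", "first", "only" and "open" are said of these compounds alone.

Four close relatives share a core of two fused rings carrying a chloromethylbenzyl group; they differ in how the core is joined and in where it carries chlorine. Compound 1 `ClCc1ccccc1Cn1cnc2c(Cl)nc(Cl)nc21`, compound 2 `ClCc1ccccc1Cn1cnc2c(Cl)ncnc21` and compound 3 `ClCc1ccccc1Cn1cnc2ncnc(Cl)c21` have been tested in a functional assay on MCF7 cells (Homo sapiens) for cytotoxicity, read by sulforhodamine B assay, with a stated time of 48 h (on this read-out higher numbers stand for weaker inhibition of growth and lower numbers for stronger inhibition of growth), whereas compound 4 `ClCc1ccccc1Cn1cnc2nc(Cl)nc(Cl)c21` has not.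

In this assay compound 1 gives 1820 nM. For compound 2 this assay reports only a limit, > 100000 nM, and not a number. For compound 3 it likewise reports only a limit, > 100000 nM. The difference between the cores of compound 2 and compound 3 is not broken down here.

Compound 1 differs from compound 2 by a single change, (chloro in place of hydrogen on an aromatic carbon), and this change brings an at least 54-fold lower number from compound 2 to compound 1 (1.73 log units; beyond the scatter), a step whose size is known only as a lower bound because the limit of > 100000 nM in this assay, at which 2 of the 3 values shown sit, sets the starting point.

Compound 4 differs from compound 3 by the same change, (chloro in place of hydrogen on an aromatic carbon); the surroundings of the new chlorine are described in identical words in both cases. A step of the same kind is therefore expected, resting on an at least 54-fold lower number from compound 2 to compound 1 (1.73 log units; beyond the scatter), and is estimated at an at least 33-fold lower number from compound 3 to compound 4 (1.52 log units; beyond the scatter). Compound 4 is accordingly expected to give about 3000 nM in this assay, most likely between 500 nM and 40000 nM.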

Compound 4, concentration for total growth inhibition: 2570 nM
For compound 4 the middle estimate is 1.2-fold (0.07 log units) above the measured one; measured number inside the range.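

Putting a chlorine on the core of compound 3, on the aromatic carbon between two ring nitrogen atoms, gives an at least 38-fold lower number from compound 3 to compound 4 (1.59 log units; beyond the scatter) in this assay. The same exchange had already turned compound 2, which shows no measurable growth inhibition in this test, into the clearly active compound 1, so in this small set the change carries over from one core to the other and points the same way on both. This does not show that the two steps are equal, nor how large either one truly is, since each starts from a compound that has only a limit and not a number: the limit of > 100000 nM in this assay, at which 2 of the 4 values shown sit.

The two steps can therefore be set side by side only as lower bounds, and whether the core alters the size of the gain stays unsettled: the same change on two cores in this assay, an at least 54-fold lower number (1.73 log units; beyond the scatter) from compound 2 to compound 1 and an at least 38-fold lower number (1.59 log units; beyond the scatter) from compound 3 to compound 4; the limit leaves it open whether they differ.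

The compounds shown carry only chlorine at this place, so it stays open whether a bromine, an amine or a methoxy group there would bring a similar gain. All four compounds also share the chloromethylbenzyl group, which leaves open what a plain benzyl group would do on the same cores.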